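This account rests on a few compounds, and the source may have more. Where it says the series, first, only, none or still open, it means among the compounds named here.

Working notes on the series.

Compound 1 `C=C(C)C(=O)c1ccc(OCc2nc(C)no2)cc1Cl` gives 9700 nM in a functional assay on HL-60 cells (Homo sapiens) for inhibition; on this read-out higher numbers stand for weaker inhibition of growth and lower numbers for stronger inhibition of growth. Compound 2 `C=C(C)C(=O)c1ccc(OCc2nc(-c3ccccc3)no2)cc1Cl` gives 5400 nM in this assay. Among the compounds with values here, the one change between them is phenyl in place of methyl on an aromatic carbon, and the step it made is a 1.8-fold lower number from compound 1 to compound 2 (0.25 log units; within the scatter).

Within the data shown here, compound 3 `C=C(CC)C(=O)c1ccc(OCc2nc(C)no2)c(Cl)c1Cl` gives 2300 nM in this assay, the lowest of the three numbers so far. The difference between the core of compound 3 and the core of compound 1 is not broken down here; the values of compound 3 and compound 2 show a gap beyond the scatter, and the gap from compound 3 to compound 1 is wider still.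

Compound 4 `C=C(CC)C(=O)c1ccc(OCc2nc(-c3ccccc3)no2)c(Cl)c1Cl` is not yet measured in this assay. It differs from compound 3 by phenyl in place of methyl on an aromatic carbon, which is the same change, at the same place on the five-membered aromatic ring with two nitrogen and one oxygen, as the change from compound 1 to compound 2. On the shared core of compounds 1 and 2 that change is within the scatter, so a step of about a 1.6-fold lower number from compound 3 to compound 4 (0.22 log units; within the scatter) is expected from compound 3 to compound 4, resting on a 1.8-fold lower number from compound 1 to compound 2 (0.25 log units; within the scatter). Compound 4 is estimated at 1400 nM, with a range from 500 nM to 3500 nM expected.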

Compound 4, concentration for 50% growth inhibition: 1700 nM
For compound 4 the middle estimate is 1.2-fold (0.08 log units) below the measured one, within the range that was stated.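

In this assay, phenyl in place of methyl on an aromatic carbon gives a 1.4-fold lower number from compound 3 to compound 4 (0.13 log units; within the scatter) on the second core. Set beside the earlier step, the change carries from one core to the other with no difference that can be told apart: the same change on two cores in this assay, a 1.8-fold lower number (0.25 log units; within the scatter) from compound 1 to compound 2 and a 1.4-fold lower number (0.13 log units; within the scatter) from compound 3 to compound 4, 1.3-fold (0.12 log units) apart, within the scatter of two such steps

Within the data shown here, both steps lie within the scatter, so the two cores agree only in that this change produces no step that can be read as real; this does not show that phenyl lowers the number on either core, and two cores make no rule for the whole series.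

On these data alone, only methyl and phenyl stand at this place on the five-membered aromatic ring, so what an amine, a carboxylic acid or a longer chain would do there remains open. As far as these compounds go, whether a change giving a step beyond the scatter would carry between these cores, and whether this one holds on a third core, also remains open.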